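Methyl on the ring carbon: cytotoxicity across two cores

This account rests on a few compounds, and the source may have more. Where it says the series, first, only, none or still open, it means among the compounds named here.

Compound 1 `COc1ncnc(Nc2ccc(Cl)c(OCC=C(C)C)c2)n1` and compound 2 `COc1nc(C)nc(Nc2ccc(Cl)c(OCC=C(C)C)c2)n1` share one core; in an ADME assay on MT2 cells (Homo sapiens) for cytotoxicity (on this read-out lower numbers stand for higher toxicity in this test and higher numbers for lower toxicity in this test), compound 1 gives 18000 nM and compound 2 gives 12000 nM. The change between them is methyl in place of hydrogen on an aromatic carbon and it made a 1.5-fold lower number from compound 1 to compound 2 (0.18 log units; within the scatter). Compound 3 `CC(C)=CCOc1cc(Nc2ncccn2)ccc1Cl` carries another core; the difference between the two cores is not broken down here. In this assay compound 3 gives 2500 nM, the lowest of the three numbers. Compound 4 `CC(C)=CCOc1cc(Nc2nccc(C)n2)ccc1Cl` is not yet measured; it differs from compound 3 by methyl in place of hydrogen on an aromatic carbon. This is the same kind of change as that in the first core, though the place is not the same: there the carbon sits between two ring nitrogen atoms and meta to a methoxy group, here it sits next to the ring nitrogen in a ring with 2 nitrogen. The step expected in this assay is a 1.3-fold lower number from compound 3 to compound 4 (0.10 log units; within the scatter), set beside the earlier one, and rests on the measured step of a 1.5-fold lower number from compound 1 to compound 2 (0.18 log units; within the scatter). Compound 4 is thus estimated at 2000 nM, expected to lie between 800 nM and 5000 nM.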

Compound 4, half-maximal cytotoxic concentration: 150 nM
For compound 4 the middle estimate is 13-fold (1.12 log units) above the measured one; measured number below the stated range.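

Methyl in place of hydrogen on an aromatic carbon does not carry over in size between the two cores in this assay: the same change on two cores in this assay, a 1.5-fold lower number (0.18 log units; within the scatter) from compound 1 to compound 2 and a 17-fold lower number (1.22 log units; beyond the scatter) from compound 3 to compound 4, 11-fold (1.05 log units) apart, beyond the scatter of two such steps. On the core of compound 3 the change gives a large step, a 17-fold lower number from compound 3 to compound 4 (1.22 log units; beyond the scatter), and a step read on one of these cores therefore gives no reliable size for the other. With a single pair on each core and the methyl at a different place on each, this does not separate the effect of the core from that of the place, and it gives no cause for the gap.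

Open, as far as these compounds go, is whether an ethyl group or an amine at the same place on the core of compound 3 gives a step of similar size. Also open, from the compounds shown here alone, is whether the step from pyrimidin-2-yl to 4-methylpyrimidin-2-yl holds with fluorine in place of the chlorine.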